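Replacing dipropylamino with a methoxypiperidine ring

This account rests on a few compounds, and the source may have more. Where it says the series, first, only, none or still open, it means among the compounds named here.

Measured so far in a functional assay on CHO-K1 cells for antagonist activity at transient receptor potential cation channel subfamily V member 1 (Homo sapiens), read by FLIPR; a lower number here means a stronger inhibitor, a higher number a weaker inhibitor:
compound 1, `CCCN(CCC)c1nc(C(F)(F)F)ccc1CNC(=O)C(C)c1ccc(NS(C)(=O)=O)c(F)c1`, compound 1 gives 0.2 nM;
compound 2, `CC1CCCN1c1nc(C(F)(F)F)ccc1CNC(=O)[C@@H](C)c1ccc(NS(C)(=O)=O)c(F)c1`, compound 2 gives 0.3 nM;
compound 3, `C[C@@H](C(=O)NCc1ccc(C(F)(F)F)nc1N1CCC(c2ccccc2)CC1)c1ccc(NS(C)(=O)=O)c(F)c1`, compound 3 gives 7.5 nM.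

Among these three, compound 1 carries the lowest number. Compound 2 sits so close to it that the two are not separated by the usual scatter, whereas compound 3, which bears the largest ring on the shared core, lies clearly apart, beyond the scatter.

Compound 4, `COC1CCN(c2nc(C(F)(F)F)ccc2CNC(=O)C(C)c2ccc(NS(C)(=O)=O)c(F)c2)CC1`, has not yet been measured in this assay. It differs from compound 1 in one place: 4-methoxypiperidin-1-yl in place of dipropylamino on an aromatic carbon. The change trades an open-chain amine for a ring, as in compound 2 and compound 3, but the ring here carries only a methoxy group rather than a phenyl.

Given that compound 2 stays close to compound 1 while compound 3 falls well away, a modest weakening is expected: the step from compound 1 to compound 4 is estimated at a 5.0-fold higher number from compound 1 to compound 4 (0.70 log units; beyond the scatter). Compound 4 is therefore expected to give about 1 nM, within a range of 0.2 nM to 5 nM.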

Compound 4, inhibition constant: 2.4 nM
Beside the measured number, compound 4's estimate is 2.4-fold (0.38 log units) below it, within the range that was stated.
By their numbers in this assay, from the lowest: compounds 1 and 2 (each within the scatter of the next); then compound 4; then compound 3.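

In this assay, 4-methoxypiperidin-1-yl in place of dipropylamino gives a 12-fold higher number from compound 1 to compound 4 (1.08 log units; beyond the scatter), the first step shown that changes only this one place, on an aromatic carbon next to the ring nitrogen. It shows that the potency of compound 1 is not kept across this change, a large loss for a swap that adds only a little in heavy-atom count. The entering group brings a ring and an oxygen in the same change, so the step cannot be divided between them, and no measurement here accounts for it.

A plain piperidine without the methoxy group would show what the ring alone does, and an open-chain amine carrying a methoxyethyl chain would show what the oxygen does without a ring. As far as these compounds go, whether either stays nearer to compound 1 remains open.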